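A few compounds are considered here, and "the series" means these few. Any claim that something is new, unique, unknown or untested is made for them only; others in the source may bear on it.

Compound 1 `COC(=O)N[C@H](C(=O)N1CCC[C@H]1C(=O)Nc1ccc([C@H]2CC[C@H](c3ccc(NC(=O)[C@@H]4CCCN4C(=O)[C@@H](NC(=O)OC)C(C)(C)C)cc3)N2c2ccc(F)cc2)cc1)C(C)(C)C` and compound 2 `COC(=O)N[C@H](C(=O)N1CCC[C@H]1C(=O)Nc1ccc([C@@H]2CC[C@@H](c3ccc(NC(=O)[C@@H]4CCCN4C(=O)[C@@H](NC(=O)OC)[C@H]4CCOC4)cc3)N2c2ccc(F)cc2)cc1)[C@H]1CCOC1` share a core, and both were examined in an ADME assay on the whole organism for pharmacokinetics, with Rattus norvegicus as the target, at a dose of 3 mg/kg by the intravenous route; on this read-out higher numbers stand for wider distribution into tissues and lower numbers for narrower distribution. Compound 1 gives 1 L/kg, while compound 2 gives 0.5 L/kg; these two numbers lie within the usual scatter of each other, so nothing separates them. Compound 3 `COC(=O)N[C@H](C(=O)N1CCC[C@H]1C(=O)Nc1ccc([C@H]2CC[C@H](c3ccc(NC(=O)[C@@H]4CCCN4C(=O)[C@@H](NC(=O)OC)[C@H]4CCOC4)cc3)N2c2ccc(F)cc2)cc1)[C@H]1CCOC1` has not yet been measured. It differs from compound 2 in the following way: the two compounds have the same atoms and bonds and differ only in configuration as drawn: 2 of 8 stereo elements differ; a stereocentre at a saturated ring carbon is drawn S in compound 2 and R in compound 3; a stereocentre at a saturated ring carbon is drawn S in compound 2 and R in compound 3. For such a change in configuration alone, with no atom added or removed, the expected step from compound 2 to compound 3 is a 1.2-fold higher number from compound 2 to compound 3 (0.08 log units; within the scatter), that is, none beyond the scatter. Compound 3 is therefore estimated at 0.6 L/kg, ranging from 0.3 L/kg to 1.2 L/kg.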

Compound 3, volume of distribution at steady state: 1.5 L/kg
Beside the measured number, compound 3's estimate is 2.5-fold (0.40 log units) below it; the whole stated range lies below it.
By their numbers in this assay, from the lowest: compounds 2, 1 and 3 (each within the scatter of the next, the first and the last beyond it).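

In this assay, there is a 3.0-fold higher number from compound 2 to compound 3 (0.48 log units; beyond the scatter), a step that adds and removes no atom. Compound 1 and compound 2 differ in more than configuration and offer no such clean reading. This step belongs to the two stereocentres at saturated ring carbons alone: the fact that compounds 2 and 3 differ only in the configuration as drawn

Going by these compounds, the two stereocentres change together, and which of them carries the step stays open. Also open, on these data alone, is whether the same change in configuration would give a similar step with an amine or a carboxylic acid in the side groups.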